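This account rests on a few compounds, and the source may have more. Where it says the series, first, only, none or still open, it means among the compounds named here.

Measured in a functional assay on PC-3 cells (Homo sapiens) for antiproliferative activity, read by MTT assay, with a stated time of 24 h; on this read-out higher numbers stand for weaker inhibition and lower numbers for stronger inhibition:
- Compound 1 `CCn1c(C(=O)N[C@@H](C)C(=O)OC)ccc1C(CC)(CC)c1ccc(OCS(=O)(=O)c2ccccc2)c(C)c1`: > 50000 nM (a limit, not a number)
- Compound 2 `CCn1c(C(=O)N[C@H](C)CO)ccc1C(CC)(CC)c1ccc(OCS(=O)(=O)c2ccccc2)c(C)c1`: 7790 nM
- Compound 3 `CCn1c(C(=O)N[C@H](CO)C(C)C)ccc1C(CC)(CC)c1ccc(OCS(=O)(=O)c2ccccc2)c(C)c1`: 7300 nM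

Compound 3 stands level with compound 2, as a 1.1-fold lower number from compound 2 to compound 3 (0.03 log units; within the scatter) shows. Together they are the only compounds here with actual numbers.

Compound 4 `CCn1c(C(=O)N[C@@H](C)C(=O)O)ccc1C(CC)(CC)c1ccc(OCS(=O)(=O)c2ccccc2)c(C)c1` differs from compound 3 at one place: 1-carboxyethyl in place of 1-(hydroxymethyl)-2-methylpropyl on an amide-type nitrogen. In short, 1-carboxyethyl stands in place of 1-(hydroxymethyl)-2-methylpropyl on an amide-type nitrogen.

Two measured changes at that same place bear on this: an at least 6.4-fold lower number from compound 1 to compound 2 (0.80 log units; beyond the scatter) and an at least 6.8-fold lower number from compound 1 to compound 3 (0.83 log units; beyond the scatter). Both replace 1-(methoxycarbonyl)ethyl with a group carrying hydroxymethyl. Within the data shown here, by name, the 1-carboxyethyl of compound 4 is closer to that 1-(methoxycarbonyl)ethyl than to either hydroxymethyl group, although no compound with 1-carboxyethyl has been measured. Much of the gain seen in an at least 6.8-fold lower number from compound 1 to compound 3 (0.83 log units; beyond the scatter) is therefore expected to be lost.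

The expected change, towards weaker inhibition, is an estimated 4.1-fold higher number from compound 3 to compound 4 (0.61 log units; beyond the scatter). For compound 4 the estimated value is 30000 nM, with an expected range from 10000 nM to 80000 nM.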

Compound 4, half-maximal inhibitory concentration: 16800 nM
For compound 4 the middle estimate is 1.8-fold (0.25 log units) above the measured one, within the range that was stated.
By their numbers in this assay, from the lowest: compounds 3 and 2 (each within the scatter of the next); then compound 4. At a limit, above all of these: compound 1.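

Taking the methyl off the ester of compound 1 gives a real number in this assay, which is the first view of how the carboxyl end itself behaves at this amide-type nitrogen: an at least 2.9-fold lower number from compound 1 to compound 4 (0.47 log units; beyond the scatter). The value of compound 1 is a limit, not a number: the limit of > 50000 nM in this assay, at which 1 of the 4 values shown sits. Even so, 1-carboxyethyl does not match the two groups carrying hydroxymethyl, as a 2.3-fold higher number from compound 3 to compound 4 (0.36 log units; beyond the scatter) and a 2.2-fold higher number from compound 2 to compound 4 (0.33 log units; beyond the scatter) show, so the three kinds of end separate here, with hydroxymethyl giving the lowest numbers, then the carboxylic acid, then the methyl ester at its limit.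

The compounds shown leave open how an amine or a primary amide would fare at this end of the chain. They also leave open whether a longer chain, or the branched chain of compound 3 carrying a carboxylic acid, would shift the number.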